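Swapping the methylphenyl hydrazone for a difluorophenyl group

The source may hold more compounds than are shown below. What is called first, only, known or untested is meant among the compounds shown, and "the series" means these compounds.

Compound 1 `Cc1cccc(/C=N/Nc2ncc3c(n2)n(C2CCCC2)c(=O)c(=O)n3C)c1`: 34500 nM
Compound 2 `Cn1c(=O)c(=O)n(C2CCCC2)c2nc(N/N=C/c3ccc(F)cc3Br)ncc21`: 6590 nM
Compound 3 `Cn1c(=O)c(=O)n(C2CCCC2)c2nc(N/N=C/c3ccc(O)c(Br)c3)ncc21`: 12800 nM

In a functional assay on A549 cells (Homo sapiens) for antiproliferative activity, read by MTT assay (on this read-out lower numbers stand for stronger inhibition and higher numbers for weaker inhibition), compound 1 gives 34500 nM, the highest of the three numbers. Compound 2 gives 6590 nM and compound 3 gives 12800 nM. Compound 4 `Cn1c(=O)c(=O)n(C2CCCC2)c2nc(N/N=C/c3ccc(F)cc3F)ncc21` differs from compound 1 in one place: 2,4-difluorophenyl in place of 3-methylphenyl on a carbon with a double bond to nitrogen. Going by the values given here, the steps that bear on this change are a 5.2-fold lower number from compound 1 to compound 2 (0.72 log units; beyond the scatter) and a 2.7-fold lower number from compound 1 to compound 3 (0.43 log units; beyond the scatter), while the gap between the two substituted analogues is a 1.9-fold higher number from compound 2 to compound 3 (0.29 log units; within the scatter). Both replacements of the 3-methylphenyl group lowered the number beyond the scatter, and the 2,4-difluorophenyl group most closely resembles the 2-bromo-4-fluorophenyl group of compound 2. A modest lower number is therefore expected for compound 4, a 3.5-fold lower number from compound 1 to compound 4 (0.54 log units; beyond the scatter). The estimate for compound 4 is 10000 nM, with a range from 4000 nM to 25000 nM.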

Compound 4, half-maximal inhibitory concentration: 18300 nM
Estimate against measurement, compound 4: 1.8-fold (0.26 log units) below, and the stated range covers the measured number.
By their numbers in this assay, from the lowest: compounds 2, 3, 4 and 1 (each within the scatter of the next, the first and the last beyond it).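

Against the 3-methylphenyl group, the 2,4-difluorophenyl group gives only a 1.9-fold lower number from compound 1 to compound 4 (0.28 log units; within the scatter), and against the 3-bromo-4-hydroxyphenyl group it gives a 1.4-fold higher number from compound 3 to compound 4 (0.16 log units; within the scatter), so neither replacement separates it from these groups. Going by these compounds alone, the single atom exchange does separate two compounds: fluoro in place of bromo on an aromatic carbon gives a 2.8-fold higher number from compound 2 to compound 4 (0.44 log units; beyond the scatter), which ties the low number of compound 2 to its bromo group rather than to the fluoro group it also carries. Nothing measured here explains this step.

From the compounds shown here alone, it stays open whether that step holds for bromo at other places on the phenyl ring. Going by these compounds, how a chloro, methoxy or amine group on the ring would compare also remains unknown.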